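Methoxy Removal on a Shared Core: Growth Inhibition Outlook

The source may report more compounds than this note shows. Statements on the series, on what has been measured and on what is new or still open speak of the compounds shown alone.

Measured compounds in a functional assay on HCT-116 cells (Homo sapiens) for inhibition, read by sulforhodamine B assay, with a stated time of 48 h, tested at 50 uM; on this read-out higher numbers stand for more inhibition of growth at the one concentration tested and lower numbers for less inhibition of growth:
- compound 1 `O=C1C(=O)N(CCCCn2cc(COc3cc(=O)oc4ccccc34)nn2)c2ccc(F)cc21`: 67%
- compound 2 `O=C1C(=O)N(CCCn2cc(COc3cc(=O)oc4ccccc34)nn2)c2ccc(F)cc21`: 75%
- compound 3 `COc1ccc2c(c1)C(=O)C(=O)N2CCCCCn1cc(COc2cc(=O)oc3ccccc23)nn1`: 25%

Compound 3 stands lowest of the three numbers. Its nearest neighbour is compound 1, whose value lies beyond the scatter above it, and the gap to compound 2 is wider still. Going by the values given here, compounds 1 and 2 differ from compound 3 in more than one place, so no single step between measured compounds is known, and their higher values cannot be tied to one change.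

Compound 4 `O=C1C(=O)N(CCCCCn2cc(COc3cc(=O)oc4ccccc34)nn2)c2ccccc21` is the unmeasured neighbour of compound 3. The change is hydrogen in place of methoxy on an aromatic carbon. Only compound 3 is known on this side of the set, and nothing measured shows what hydrogen in place of methoxy does here. With the other two compounds both well above compound 3, a modest rise is expected, but with wide uncertainty. The step from compound 3 to compound 4 in this assay is estimated as a number 15 percentage points higher from compound 3 to compound 4 (beyond the scatter). Compound 4 is therefore expected to show 40%, between 15% and 70%.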

Compound 4, percent growth inhibition at one concentration: 65%
Beside the measured number, compound 4's estimate is 25 percentage points below it, within the range that was stated.
By their numbers in this assay, from the lowest: compound 3; then compounds 4, 1 and 2 (each within the scatter of the next).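

Within this assay, hydrogen in place of methoxy on this aromatic carbon, meta to a fused ring and para to a fused ring, gives a number 40 percentage points higher from compound 3 to compound 4 (beyond the scatter). The earlier compounds shown here could not tie the low value of compound 3 to any single change, whereas this pair, which differs in one place only, shows that exchanging this one group with the chain unchanged is enough to produce a large step. No available evidence bears on what lies behind this step.

The compounds shown leave open whether another group on this carbon, such as a chlorine atom or an amine, would give a number closer to that of compound 3 or of compound 4. They also leave open whether the same exchange would produce a step of similar size on a shorter chain.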